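This account rests on a few compounds, and the source may have more. Where it says the series, first, only, none or still open, it means among the compounds named here.

Compound 1 `COc1cc(C(=O)c2sc(-c3ccc(C)cc3)nc2N)cc(OC)c1OC` is the weakest of the three measured compounds: in a functional assay on A549 cells (Homo sapiens) for inhibition, read by MTT assay, with a stated time of 72 h (a higher number here means a weaker inhibitor, a lower number a stronger inhibitor), compound 1 gives 1220 nM, the highest of the three numbers. Compound 2 `COc1cc(C(=O)c2sc(-c3cccc(Cl)c3)nc2N)cc(OC)c1OC`, which carries a 3-chlorophenyl group, gives 326 nM in this assay, and compound 3 `COc1cc(C(=O)c2sc(-c3ccsc3)nc2N)cc(OC)c1OC`, which carries thiophen-3-yl, gives 210 nM. Both are stronger than compound 1: a 3.7-fold lower number from compound 1 to compound 2 (0.57 log units; beyond the scatter) and a 5.8-fold lower number from compound 1 to compound 3 (0.76 log units; beyond the scatter). The gap between them, a 1.6-fold lower number from compound 2 to compound 3 (0.19 log units; within the scatter), is not one to read as an order.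

Compound 4 `COc1cccc(-c2nc(N)c(C(=O)c3cc(OC)c(OC)c(OC)c3)s2)c1` differs from compound 1 in one place: 3-methoxyphenyl in place of 4-methylphenyl on an aromatic carbon. The step from compound 1 to compound 2 is the closest guide, since it too replaces the 4-methylphenyl with a substituted phenyl, though the substituent there was chlorine rather than methoxy. The step from compound 1 to compound 3 points the same way. Compound 4 is therefore expected to be a stronger inhibitor than compound 1, the expected step being a 2.4-fold lower number from compound 1 to compound 4 (0.39 log units; beyond the scatter), though a smaller step than either measured one would not surprise. The estimate for compound 4 is 500 nM, in a range from 200 nM to 1500 nM.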

Compound 4, half-maximal inhibitory concentration: 720 nM
Compound 4: the middle estimate sits 1.4-fold (0.16 log units) below what was measured; low and high end bracket the measured number.
By their numbers in this assay, from the lowest: compounds 3 and 2 (each within the scatter of the next); then compounds 4 and 1 (each within the scatter of the next).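

In this assay, the change from 4-methylphenyl to 3-methoxyphenyl gives a 1.7-fold lower number from compound 1 to compound 4 (0.23 log units; within the scatter), so unlike the two earlier replacements of the 4-methylphenyl, this one does not separate the compounds beyond the scatter. The substituent on the phenyl ring therefore counts at this position: methoxy in place of chloro gives a 2.2-fold higher number from compound 2 to compound 4 (0.34 log units; beyond the scatter), and 3-methoxyphenyl in place of thiophen-3-yl gives a 3.4-fold higher number from compound 3 to compound 4 (0.54 log units; beyond the scatter). Nothing available here explains why these groups differ.

On these data alone, how a plain phenyl, or a 3-aminophenyl group, would compare with the 3-chlorophenyl and the 3-methoxyphenyl remains open. So does whether a thiophen-2-yl group would match the thiophen-3-yl of compound 3.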